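Second trifluoromethyl on the benzamide ring of compound 3

A few compounds are considered here, and "the series" means these few. Any claim that something is new, unique, unknown or untested is made for them only; others in the source may bear on it.

Three compounds share one core and differ only in the group on the carbonyl carbon of the amide. In a functional assay on NCI/ADR-RES cells (Homo sapiens) for inhibition, read by sulforhodamine B assay, with a stated time of 48 h, tested at 10 uM (a lower number here means a stronger effect, a higher number a weaker effect of the compound at the concentration tested), compound 1 `COc1cc(Cl)cc(-c2nn(-c3cccc(NC(=O)c4ccc(Cl)c(Cl)c4)c3)cc2-c2ccncc2)c1` gives 61.4%. Compound 2 `COc1cc(Cl)cc(-c2nn(-c3cccc(NC(=O)Nc4ccc(Cl)c(C(F)(F)F)c4)c3)cc2-c2ccncc2)c1`, a urea rather than an amide, gives 6.07% in this assay, which is a number 55.3 percentage points lower from compound 1 to compound 2 (beyond the scatter). Compound 3 `COc1cc(Cl)cc(-c2nn(-c3cccc(NC(=O)c4cccc(C(F)(F)F)c4)c3)cc2-c2ccncc2)c1` gives 46.7% in this assay, the second highest of the three numbers, sitting a number 14.7 percentage points lower from compound 1 to compound 3 (beyond the scatter) and a number 40.6 percentage points higher from compound 2 to compound 3 (beyond the scatter).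

Compound 4 `COc1cc(Cl)cc(-c2nn(-c3cccc(NC(=O)c4cc(C(F)(F)F)cc(C(F)(F)F)c4)c3)cc2-c2ccncc2)c1` is not yet measured. It differs from compound 3 in one place: trifluoromethyl in place of hydrogen on an aromatic carbon. Among the compounds with values here, the only step that bears on this is the modest one between compound 1 and compound 3, which also changed substituents on the same ring; no measured step shows the effect of a second trifluoromethyl. A modest lowering is therefore expected, the step from compound 3 to compound 4 being estimated as a number 8.7 percentage points lower from compound 3 to compound 4 (within the scatter) in this assay. Compound 4 is expected to give about 38% in this assay, within a range from 15% to 60%.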

Compound 4, a percentage reported as activity, at one concentration (the size of the read-out at that concentration, not a potency): 67.8%
Compound 4: middle estimate off by 29.8 percentage points, on the low side, outside the stated range (above it).
By their numbers in this assay, from the lowest: compound 2; then compound 3; then compounds 1 and 4 (each within the scatter of the next).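

In this assay, trifluoromethyl in place of hydrogen, meta to a trifluoromethyl group, gives a number 21.1 percentage points higher from compound 3 to compound 4 (beyond the scatter), so here the added group goes with a weaker effect at the concentration tested. The earlier change on this ring gave a number 14.7 percentage points lower from compound 1 to compound 3 (beyond the scatter), so a trifluoromethyl group on this ring does not go with a stronger effect in every case, and a second one brought no further gain. Nothing measured on these compounds accounts for the rise.

The compounds shown leave open whether a fluorine, a methoxy group or an amine at this same position would also raise the number. They also leave open how a urea such as compound 2 would respond to a second trifluoromethyl on its ring.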